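The source may hold more compounds than are shown below. What is called first, only, known or untested is meant among the compounds shown, and "the series" means these compounds.

Two related compounds have been tested so far in a functional assay on HeLa cells (Homo sapiens) for antiproliferative activity, read by MTT assay, with a stated time of 72 h; on this read-out higher numbers stand for weaker inhibition and lower numbers for stronger inhibition. Compound 1 `CNc1nc(-c2cc(OC)c(OC)c(OC)c2)c(-c2ccc(OC)cc2)s1`, which bears a 4-methoxyphenyl group, gives 70.1 nM. Compound 2 `COc1cc(-c2nc(N(C)C)sc2-c2ccc(C)cc2)cc(OC)c1OC`, which bears a 4-methylphenyl group, gives 4140 nM. That is the higher of the two numbers, so compound 2 is the weaker inhibitor, and the gap lies beyond the usual scatter of repeat measurements. Compound 3 `COc1ccc(-c2sc(N(C)C)nc2-c2cc(OC)c(OC)c(OC)c2)cc1` differs from compound 2 in one place: methoxy in place of methyl on an aromatic carbon. This puts methoxy in place of methyl on an aromatic carbon, turning 4-methylphenyl into 4-methoxyphenyl. Among the measured compounds shown here, no measured pair shows this change alone, so the expectation is uncertain. Compound 1 gives 70.1 nM with the 4-methoxyphenyl group, so a fall in the number beyond the scatter is expected. The estimated step is a 10-fold lower number from compound 2 to compound 3 (1.01 log units; beyond the scatter). Compound 3 is expected at 400 nM, within an estimated range of 80 nM to 2000 nM.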

Compound 3, half-maximal inhibitory concentration: 3370 nM
The estimate for compound 3 lay 8.4-fold (0.93 log units) below the measured number, outside the stated range (above it).
By their numbers in this assay, from the lowest: compound 1; then compounds 3 and 2 (each within the scatter of the next).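

In this assay, putting methoxy in place of methyl on the aromatic ring gives a 1.2-fold lower number from compound 2 to compound 3 (0.09 log units; within the scatter), so with two methyl groups on the nitrogen, 4-methylphenyl and 4-methoxyphenyl cannot be told apart at this position. The change that matters among the single-place comparisons lies elsewhere: adding a methyl group to the nitrogen gives a 48-fold higher number from compound 1 to compound 3 (1.68 log units; beyond the scatter), a large loss of inhibition from one added methyl group while the 4-methoxyphenyl group stays in place. No measurement here explains either step.

Among the compounds shown here, it remains open whether methyl and methoxy on the aromatic ring would still match when the nitrogen carries only one methyl group. Going by these compounds, how chlorine or a hydroxyl group would behave at this ring position, or an ethyl group or an unsubstituted amine at the nitrogen, also remains open.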